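Thromboxane receptor sulfonamides: chain exchange on the shared core

A few compounds are considered here, and "the series" means these few. Any claim that something is new, unique, unknown or untested is made for them only; others in the source may bear on it.

Measured so far:
- compound 1, `O=C(O)COCCCC[C@H]1[C@H](F)CC[C@@H]1NS(=O)(=O)c1ccc(F)cc1`: 1800 nM
- compound 2, `O=C(O)CCC/C=C\C[C@H]1[C@H](F)CC[C@@H]1NS(=O)(=O)c1ccccc1`: 1100 nM

Both compounds were run in a functional assay on a cell-free system (plasma) for inhibition of thromboxane A2 receptor (Homo sapiens), read by turbidimetry; a lower number here means a stronger inhibitor, a higher number a weaker inhibitor. Compound 2 holds the lower of the two numbers, but compound 1 stands within the scatter of it, so no order between the two can be claimed.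

Compound 3, `O=C(O)COCCCC[C@H]1[C@H](F)CC[C@@H]1NS(=O)(=O)c1ccccc1`, has not been measured. It differs from compound 2 in one place: 3-(carboxymethoxy)propyl in place of 5-carboxypent-1-en-1-yl on a saturated chain carbon bound to a saturated ring carbon. The aryl sulfonamide of compound 2 is kept. Compound 1 carries the same 3-(carboxymethoxy)propyl chain as compound 3 and differs from it only in the aryl fluorine; in this assay compound 1 gives 1800 nM. Among the measured compounds shown here, no pair that isolates the chain exchange alone has been measured, so the size of the step cannot be read from the series.

Expectation: the chain exchange from compound 2 to compound 3 is estimated to give a small rise, a 1.6-fold higher number from compound 2 to compound 3 (0.21 log units; within the scatter), not beyond the scatter. For compound 3 the estimated value in this assay is 1800 nM, with a range from 800 nM to 4000 nM.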

Compound 3, half-maximal inhibitory concentration: 1700 nM
For compound 3 the middle estimate is 1.1-fold (0.02 log units) above the measured one; the range from low to high includes it.
By their numbers in this assay, from the lowest: compounds 2, 3 and 1 (each within the scatter of the next).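

In this assay, the exchange of 5-carboxypent-1-en-1-yl for 3-(carboxymethoxy)propyl on a saturated chain carbon bound to a saturated ring carbon can now be read alone, with the aryl sulfonamide kept (a 1.5-fold higher number from compound 2 to compound 3 (0.19 log units; within the scatter)), and at this place the two chains are not told apart by this read-out. The new compound also isolates hydrogen in place of fluoro on an aromatic carbon with the 3-(carboxymethoxy)propyl chain held constant (a 1.1-fold lower number from compound 1 to compound 3 (0.02 log units; within the scatter)), so on this chain the aryl fluorine gives no difference that can be separated from the scatter. No measured property or other supporting data bear on either step.

The compounds shown leave open whether a longer chain at this place, or a tetrazole in place of the carboxylic acid, would give a step beyond the scatter. They also leave open whether fluoro on an aromatic carbon behaves the same way with the 5-carboxypent-1-en-1-yl chain, and whether a methoxy or chloro group there would separate from hydrogen.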